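Lengthening the ester chain in an anilide series

The compounds below may be only part of what the source reports. "The series", "measured", "known", "first", "only" and "open" are said of these compounds alone.

The four compounds share one core, an amide of an aromatic amine bearing two isopropyl groups, joined to an ester whose alcohol part varies. Compound 1 `CCOC(=O)CC(=O)Nc1c(C(C)C)cccc1C(C)C` carries the ethyl ester, compound 3 `CCCCCCCCOC(=O)CC(=O)Nc1c(C(C)C)cccc1C(C)C` the octyl ester, compound 2 `CCCCCCCCCCOC(=O)CC(=O)Nc1c(C(C)C)cccc1C(C)C` the decyl ester, and compound 4 `CCCCCCCCCCCCCCCCOC(=O)CC(=O)Nc1c(C(C)C)cccc1C(C)C` the hexadecyl ester, which has not yet been measured.

In an assay on microsomes from intestine for inhibition of acyl-CoA:cholesterol acyltransferase (Oryctolagus cuniculus) (a higher number here means a weaker inhibitor, a lower number a stronger inhibitor), compound 1 gives 1800 nM. Compound 3 gives 260 nM, and compound 2 gives 53 nM. The change hexyl in place of hydrogen on a saturated chain carbon, two bonds along the chain from an oxygen next to a carbonyl group sets compound 3 apart from compound 1, with a step of a 6.9-fold lower number from compound 1 to compound 3 (0.84 log units; beyond the scatter). The change octyl in place of hydrogen on a saturated chain carbon, two bonds along the chain from an oxygen next to a carbonyl group gave a step of a 34-fold lower number from compound 1 to compound 2 (1.53 log units; beyond the scatter). Between compounds 2 and 3 the step is a 4.9-fold higher number from compound 2 to compound 3 (0.69 log units; beyond the scatter).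

The change from compound 3 to compound 4 is octyl in place of hydrogen on a saturated chain carbon, eight bonds along the chain from an oxygen next to a carbonyl group. It is the same kind of change as from compound 1 to compound 2, but its place differs: eight bonds along the chain rather than two bonds along the chain from an oxygen next to a carbonyl group. Because the step of a 4.9-fold higher number from compound 2 to compound 3 (0.69 log units; beyond the scatter) already shows a smaller gain once the chain is long, a step of only a 2.4-fold lower number from compound 3 to compound 4 (0.37 log units; beyond the scatter) is expected for compound 4. Compound 4 is estimated at 110 nM, between 20 nM and 600 nM.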

Compound 4, half-maximal inhibitory concentration: 35 nM
Compound 4: the middle estimate sits 3.1-fold (0.50 log units) above what was measured; measured number inside the range.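

In this assay, octyl in place of hydrogen on the octyl ester gives a 7.4-fold lower number from compound 3 to compound 4 (0.87 log units; beyond the scatter), a clear step, yet the same change on the ethyl ester gave a larger one: the same change on two cores in this assay, a 34-fold lower number (1.53 log units; beyond the scatter) from compound 1 to compound 2 and a 7.4-fold lower number (0.87 log units; beyond the scatter) from compound 3 to compound 4, 4.6-fold (0.66 log units) apart, beyond the scatter of two such steps

Hexyl in place of hydrogen on the decyl ester gives a 1.5-fold lower number from compound 2 to compound 4 (0.18 log units; within the scatter), so compound 2 and compound 4 cannot be told apart, although the same change on the ethyl ester gave a step beyond the scatter: the same change on two cores in this assay, a 6.9-fold lower number (0.84 log units; beyond the scatter) from compound 1 to compound 3 and a 1.5-fold lower number (0.18 log units; within the scatter) from compound 2 to compound 4, 4.6-fold (0.66 log units) apart, beyond the scatter of two such steps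

Across these four compounds, then, the same added chain does not carry the same step from one core to another, and its size depends on the ester it is added to, but two pairs for each change give no general rule and do not show why the steps differ.

A dodecyl ester, or a chain longer than hexadecyl, could show whether the numbers stay level or turn upward again. The compounds shown also leave open how a benzyl ester, or an amide in place of the ester, would behave in this assay.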